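Amide to sulfonamide on the ring nitrogen of the core

The source may hold more compounds than are shown below. What is called first, only, known or untested is meant among the compounds shown, and "the series" means these compounds.

Measured compounds:
compound 1, `CC1CC1C(=O)N1CCc2nc(C#Cc3ccccc3)sc2C1`: in an assay on HEK293 cells for negative allosteric modulation of metabotropic glutamate receptor 5 (Homo sapiens), read by FLIPR, with a stated time of 1 h (a lower number here means a stronger inhibitor, a higher number a weaker inhibitor), compound 1 gives > 10000 nM, a limit of the assay.
compound 2, `CC1CC(C(=O)N2CCc3nc(C#Cc4ccccc4)sc3C2)C1`: in this assay compound 2 gives > 10000 nM, also a limit.
compound 3, `COC1CC(C(=O)N2CCc3nc(C#Cc4ccccc4)sc3C2)C1`: in this assay compound 3 gives > 10000 nM, again a limit.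

Compound 3 stands at the limit of > 10000 nM in this assay, at which 3 of the 3 values shown sit; no number places it against compound 1 or compound 2. The steps a step that the two limits leave unreadable from compound 1 to compound 2, a step that the two limits leave unreadable from compound 1 to compound 3 and a step that the two limits leave unreadable from compound 2 to compound 3 give no size. Compound 4, `CC(C)S(=O)(=O)N1CCc2nc(C#Cc3ccccc3)sc2C1`, differs by isopropylsulfonyl in place of (3-methoxycyclobutyl)carbonyl on an amine nitrogen in a ring. Among the measured compounds shown here, none of the measured steps touches this kind of change, and those at the acyl group are unreadable, so no direction can be read for this assay; a step of an at least 1.2-fold lower number from compound 3 to compound 4 (0.09 log units; that floor lies within the scatter) is expected only as a guess. Compound 4 is estimated at 8000 nM, between 1500 nM and 50000 nM.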

Compound 4, half-maximal inhibitory concentration: 11 nM
Compound 4: middle estimate off by 730-fold (2.86 log units), on the high side; the whole stated range lies above it.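

In this assay, the ring nitrogen of the core proves highly sensitive to what it carries, with isopropylsulfonyl in place of the acyl groups giving an at least 900-fold lower number from compound 3 to compound 4 (2.95 log units; beyond the scatter), an at least 900-fold lower number from compound 2 to compound 4 (2.95 log units; beyond the scatter) and an at least 900-fold lower number from compound 1 to compound 4 (2.95 log units; beyond the scatter). The steps among the three amides cannot be read: the limit of > 10000 nM in this assay, at which 3 of the 4 values shown sit.

Each step changes both the linking group and the carbon group on it, so the sulfonyl link and the isopropyl group remain unseparated, and an isobutyryl amide would address this. Going by these compounds, whether methylsulfonyl or a longer chain on the sulfonyl keeps the activity of compound 4 at 11 nM remains open.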